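Changing the aryl group on the triazole of compound 2

This account rests on a few compounds, and the source may have more. Where it says the series, first, only, none or still open, it means among the compounds named here.

Of the compounds shown here, two have been tested in a functional assay on A549 cells (Homo sapiens) for antiproliferative activity, read by MTT assay, with a stated time of 48 h; a lower number here means a stronger inhibitor, a higher number a weaker inhibitor. Within the data shown here, compound 2 `Cc1cccc(-n2nncc2CN2C(=O)C3(C(C#N)=C(N)Oc4c(N)cc5nc6ccccc6nc5c43)c3ccccc32)c1` gives 12300 nM in this assay, and it is the only compound with an actual number. Compound 1 `N#CC1=C(N)Oc2c(c3nc4ccccc4nc3c3ccccc23)C12C(=O)N(Cc1cnnn1-c1ccc(Cl)c(Cl)c1)c1ccccc12` reaches only a limit of the measurement, > 50000 nM, so no number is known for it; the evidence for compound 1 is the limit of > 50000 nM in this assay, at which 1 of the 2 values shown sits. Among the measured compounds shown here, since the two compounds differ in more than one place, their values say only that compound 2 is measurable and compound 1 is not.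

Compound 3 `CCc1cccc(CC)c1-n1nncc1CN1C(=O)C2(C(C#N)=C(N)Oc3c(N)cc4nc5ccccc5nc4c32)c2ccccc21` has not yet been measured. It differs from compound 2 in a single place: 2,6-diethylphenyl in place of 3-methylphenyl on an aromatic nitrogen. For the measured compounds named here, no step between measured compounds is known, so nothing in the data tells how large an effect this kind of change has. The expectation is therefore a step of a 1.2-fold lower number from compound 2 to compound 3 (0.09 log units; within the scatter), which is expected to stay within the usual scatter. Compound 3 is estimated to give about 10000 nM in this assay, with a likely range from 3000 nM to 35000 nM.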

Compound 3, half-maximal inhibitory concentration: > 50000 nM
Compound 3 ended at the assay's limit; the forecaster's own chance of this, stated with the estimate: 20%; at least 5.0-fold (0.69 log units) between middle value and limit.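

Placing 2,6-diethylphenyl instead of 3-methylphenyl on the aromatic nitrogen is the first change in this series that can be read in a single place, and in this assay it gives an at least 4.0-fold higher number from compound 2 to compound 3 (0.60 log units; beyond the scatter). This position is therefore not indifferent to the aryl group it carries: the measurable activity of compound 2 is gone in compound 3, although both groups hold one six-membered aromatic ring of carbon only and neither has a hydrogen-bond donor or acceptor, and the entering group differs in counting 10 heavy atoms against 7. The result for compound 3 is a limit of the assay and not a number, and it is the second such result in the series: the limit of > 50000 nM in this assay, at which 2 of the 3 values shown sit.

This one step does not separate the effect of having two ethyl groups from the effect of where they sit on the ring, and it gives no actual value for compound 3. The compounds shown also leave open how this position would respond to an unsubstituted phenyl, to a phenyl carrying a methoxy or hydroxyl group, or to a plain alkyl chain in place of the aryl ring.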